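Ethoxy to Dimethylamino: What Cytotoxicity to Expect

This account rests on a few compounds, and the source may have more. Where it says the series, first, only, none or still open, it means among the compounds named here.

Compound 1 `Cc1ccc2cc(CN(Cc3ccc(Cl)cc3)Cc3ccc(Cl)cc3)c(=O)[nH]c2c1`: in a toxicity assay on MDCK cells (Canis lupus familiaris) for cytotoxicity, read by crystal violet staining, with a stated time of 48 h (a lower number here means that less compound is tolerated, a higher number that more compound is tolerated), compound 1 gives > 33000 nM, which is a limit of the assay rather than a number.
Compound 2 `Cc1ccc2[nH]c(=O)c(CN(Cc3ccc(OCC(=O)O)cc3)Cc3ccc(C(C)(C)C)cc3)cc2c1`: compound 2 gives > 10000 nM, again a limit.
Compound 3 `CCOc1ccc(CN(Cc2ccc(C(C)(C)C)cc2)Cc2cc3cc(C)ccc3[nH]c2=O)cc1`: compound 3 gives > 10000 nM, also a limit.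

For the measured compounds named here, compound 3 therefore stands only at a limit, and the two other values shown are limits as well, so no compound here has a measured number. Going by the values given here, the one step between measured compounds, a step that the two limits leave unreadable from compound 2 to compound 3, cannot be read, since both ends sit at limits: the limit of > 10000 nM in this assay, at which 2 of the 3 values shown sit, describes where compounds 2 and 3 sit, and the limit of > 33000 nM in this assay, at which 1 of the 3 values shown sits, where compound 1 sits.

Compound 4 `Cc1ccc2[nH]c(=O)c(CN(Cc3ccc(N(C)C)cc3)Cc3ccc(C(C)(C)C)cc3)cc2c1` differs from compound 3 by dimethylamino in place of ethoxy on an aromatic carbon. Among the compounds with values here, no measured step covers this exchange, and the only step available is unreadable, so the expectation rests on all three measured compounds tolerating the highest concentration tested. Compound 4 is expected to behave alike, with an estimated step that the limit leaves unreadable from compound 3 to compound 4, no change beyond the scatter. The estimate for compound 4 in this assay is 15000 nM, ranging from 5000 nM to 50000 nM.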

Compound 4, half-maximal cytotoxic concentration: > 5000 nM
Compound 4 was reported as a limit; the forecaster's own chance of this, stated with the estimate: 70%; the middle value does not contradict the limit.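

No new step can be read: compound 4, like compound 2 and compound 3, sits at a limit in this assay rather than at a number, so the comparisons with compound 4 have no size. The compounds shown leave open at what concentration any of them harms these cells.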